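A few compounds are considered here, and "the series" means these few. Any claim that something is new, unique, unknown or untested is made for them only; others in the source may bear on it.

Measured in a functional assay on MCF7 cells (Homo sapiens) for cytotoxicity, read by CellTiter-Blue, with a stated time of 72 h; a lower number here means a stronger inhibitor, a higher number a weaker inhibitor:
- compound 1 `C/C=C(\C)[C@@H](O)[C@@H](C)[C@@H]1C/C=C(\C)C(=O)O[C@H](CC(C)C)C(=O)N[C@@H](C)C(=O)N(C)[C@H](Cc2ccccc2)C(=O)N(C)CC(=O)N[C@@H]([C@@H](C)CC)C(=O)N[C@H](C)C(=O)O1`: 0.29 nM
- compound 2 `C/C=C(\C)[C@H]1OC(=O)[C@@H](C)NC(=O)[C@H]([C@@H](C)CC)NC(=O)CN(C)C(=O)[C@@H](Cc2ccccc2)N(C)C(=O)[C@H](C)NC(=O)[C@@H](CC(C)C)OC(=O)/C(C)=C/C[C@H](OCSC)[C@@H]1C`: 6.3 nM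

Compound 1 has the lower number of these two, which makes it the stronger inhibitor, and its gap to compound 2 lies beyond the scatter. Compound 3 `C/C=C(\C)[C@@H](O)[C@@H](C)[C@@H]1C/C=C(\C)C(=O)O[C@H](CC(C)C)C(=O)N[C@H](C)C(=O)N(C)[C@H](Cc2ccccc2)C(=O)N(C)CC(=O)N[C@@H]([C@@H](C)CC)C(=O)N[C@H](C)C(=O)O1` has not yet been measured. Compared with compound 1, it shows the two compounds have the same atoms and bonds and differ only in configuration as drawn: 1 of 11 stereo elements differ; a stereocentre at a saturated ring carbon is drawn S in compound 1 and R in compound 3: a stereocentre at a saturated ring carbon is drawn S in compound 1 and R in compound 3. Among the compounds with values here, no measured pair isolates a change of this kind, so the size of the step in this assay remains a judgement. With compound 1 at 0.29 nM, the expectation is a move towards a higher number, beyond the scatter, though how far is very uncertain. The expected change is a 100-fold higher number from compound 1 to compound 3 (2.01 log units; beyond the scatter). For compound 3 the estimated value is 30 nM, with an expected range from 2 nM to 500 nM.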

Compound 3, half-maximal inhibitory concentration: 3690 nM
Beside the measured number, compound 3's estimate is 120-fold (2.09 log units) below it; the measured number lies above the stated range.
By their numbers in this assay, from the lowest: compound 1; then compound 2; then compound 3.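

In this assay, inverting this one saturated ring carbon from S to R gives a 13000-fold higher number from compound 1 to compound 3 (4.10 log units; beyond the scatter), so the configuration at this single position has a very large effect on the measured cytotoxicity. Within the data shown here, no earlier pair isolated a change at a stereocentre, which makes this the first direct view of how sensitive the shared core is to its three-dimensional arrangement. The step can be tied to configuration alone, because nothing else separates the pair: the fact that compounds 1 and 3 differ only in the configuration as drawn

The compounds shown do not tell whether inverting any of the other stereo elements would have an effect of similar size. They also leave open how the number would respond to a different group on this ring carbon, such as an ethyl group or an amine.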